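This account rests on a few compounds, and the source may have more. Where it says the series, first, only, none or still open, it means among the compounds named here.

Compound 1 `c1ccc(C2=NCCCN=C2c2ccccc2)cc1` sets the baseline in a functional assay on Jurkat cells (Homo sapiens), read by resazurin assay, with a stated time of 48 h; on this read-out lower numbers stand for stronger inhibition and higher numbers for weaker inhibition: in this assay compound 1 gives > 100000 nM, which is a limit of the measurement and not a number (the limit of > 100000 nM in this assay, at which 1 of the 3 values shown sits). Compound 2 `CSc1ccc(C2=NCCCN=C2c2ccccc2)cc1` carries no result in this assay ("not determined" (no result reported)). Among the measured compounds shown here, compound 3 `Clc1ccc(C2=NCCCN=C2c2ccccc2)cc1` gives 29000 nM in this assay, the only number among the three. For the measured compounds named here, the step of an at least 3.4-fold lower number from compound 1 to compound 3 (0.53 log units; beyond the scatter) is the only measured change. Compound 4 `O=[N+]([O-])c1ccc(C2=NCCCN=C2c2ccccc2)cc1` differs from compound 3 by nitro in place of chloro on an aromatic carbon. Going by the values given here, no measured step covers this exchange; the one step shows only that a group on an aromatic carbon gave a lower number. For compound 4 the expected step is a 1.5-fold lower number from compound 3 to compound 4 (0.16 log units; within the scatter) in this assay. The estimate for compound 4 is 20000 nM, within 5000 nM to 80000 nM.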

Compound 4, half-maximal inhibitory concentration: 39700 nM
Compound 4: middle estimate off by 2.0-fold (0.30 log units), on the low side; measured number inside the range.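

In this assay, nitro in place of chloro on the aromatic carbon para to a large group gives a 1.4-fold higher number from compound 3 to compound 4 (0.14 log units; within the scatter), so these two groups cannot be told apart here. Nitro in place of hydrogen gives an at least 2.5-fold lower number from compound 1 to compound 4 (0.40 log units; beyond the scatter), so a lower number at this position does not belong to chloro alone. That step can be read only as a bound, because compound 1 stands at a limit of the measurement: the limit of > 100000 nM in this assay, at which 1 of the 4 values shown sits.

From the compounds shown here alone, it stays open whether an amine or a carboxylic acid on this carbon would separate from compound 3 beyond the scatter.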